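Extending the alkoxy group on a shared bromomethyl core

The source may report more compounds than this note shows. Statements on the series, on what has been measured and on what is new or still open speak of the compounds shown alone.

Of the compounds shown here, three with one shared core have been measured in a functional assay on KBVIN cells (Homo sapiens) for antiproliferative activity, read by sulforhodamine B assay, with a stated time of 72 h; a higher number here means a weaker inhibitor of growth, a lower number a stronger inhibitor of growth. Compound 1 `COc1ccc2c(=O)cc(C(C)Br)oc2c1CBr` gives 17000 nM. Compound 2 `CCOc1ccc2c(=O)cc(C(C)Br)oc2c1CBr` gives 12800 nM in this assay, and compound 3 `CC(C)Oc1ccc2c(=O)cc(C(C)Br)oc2c1CBr` gives 11400 nM. Compound 3 holds the lowest of the three numbers, yet every step separating it from the others is small: a 1.5-fold lower number from compound 1 to compound 3 (0.17 log units; within the scatter) and a 1.1-fold lower number from compound 2 to compound 3 (0.05 log units; within the scatter), both within the scatter, as is a 1.3-fold lower number from compound 1 to compound 2 (0.12 log units; within the scatter). The three values therefore sit together, and no order between them can be read.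

Compound 4 `CC(C)COc1ccc2c(=O)cc(C(C)Br)oc2c1CBr` has not yet been measured. It differs from compound 3 by isobutyl in place of isopropyl on an oxygen on an aromatic ring. The two earlier steps that enlarged the group on the oxygen on the aromatic ring bear on this one: a 1.3-fold lower number from compound 1 to compound 2 (0.12 log units; within the scatter) and a 1.1-fold lower number from compound 2 to compound 3 (0.05 log units; within the scatter), each within the scatter. A further growth from isopropyl to isobutyl is therefore expected to give no step beyond the scatter in this assay, and the expected step is a 1.2-fold lower number from compound 3 to compound 4 (0.08 log units; within the scatter). Compound 4 is estimated at 9500 nM in this assay, with a range from 4000 nM to 22000 nM.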

Compound 4, concentration for 50% growth inhibition: 9450 nM
The estimate for compound 4 lay 1.0-fold (0.00 log units) above the measured number; the range from low to high includes it.
By their numbers in this assay, from the lowest: compounds 4, 3, 2 and 1 (each within the scatter of the next).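

At the oxygen on the aromatic ring, isobutyl in place of isopropyl leaves the reading in this assay unchanged in kind (a 1.2-fold lower number from compound 3 to compound 4 (0.08 log units; within the scatter)), so the largest group shown here still does not separate from its neighbours. The wider comparisons now available are also within the scatter (a 1.4-fold lower number from compound 2 to compound 4 (0.13 log units; within the scatter); a 1.8-fold lower number from compound 1 to compound 4 (0.26 log units; within the scatter)), which means that no order can be read anywhere in the series from methyl to isobutyl, even between its two ends, and the flat picture earlier seen among three groups now holds across four. No evidence beyond these growth-inhibition values bears on this result, so the flatness at this position can be described but not explained.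

On these data alone, it remains open whether a longer chain such as hexyl, or a chain ending in an amine or a carboxylic acid, would give a step beyond the scatter at this oxygen. All four compounds also keep the rest of the shared core, so the effect in this assay of replacing either bromine with chlorine or a hydroxyl group is equally unknown.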